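The source may hold more compounds than are shown below. What is called first, only, known or untested is meant among the compounds shown, and "the series" means these compounds.

Measured compounds:
compound 1, `Cn1cc(-c2nc3ccccc3n2C(=O)c2ccccc2Br)c2ccccc21`, 68200 nM
compound 2, `Cn1cc(-c2nc3ccccc3n2C(=O)c2cccc(Br)c2)c2ccccc21`, 61400 nM
compound 3, `Cn1cc(-c2nc3ccccc3n2C(=O)c2ccccc2Br)c2cc(Br)ccc21`, 72100 nM

All three values come from a functional assay on HepG2 cells (Homo sapiens) for inhibition, read by MTT assay, with a stated time of 24 h; on this read-out lower numbers stand for stronger inhibition of growth and higher numbers for weaker inhibition of growth. The series is built on one shared core carrying a bromine-bearing phenyl on the carbonyl carbon; compound 2 differs from compound 1 by 3-bromophenyl in place of 2-bromophenyl on a carbonyl carbon, and compound 3 differs from compound 1 by bromo in place of hydrogen on an aromatic carbon. Neither change moves the read-out by an amount worth noting: a 1.1-fold lower number from compound 1 to compound 2 (0.05 log units; within the scatter) and a 1.1-fold higher number from compound 1 to compound 3 (0.02 log units; within the scatter), so the three compounds sit in one cluster in this assay and no order among them can be drawn.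

Compound 4, `Cn1cc(-c2nc3ccccc3n2C(=O)c2cccc(Br)c2)c2cc(Br)ccc21`, has not yet been measured. It differs from compound 3 by 3-bromophenyl in place of 2-bromophenyl on a carbonyl carbon, the same change that separates compound 2 from compound 1; the surroundings of the carbonyl carbon read identically in both pairs, so this is the same change made on a core that itself differs from the core of compound 1 by bromo in place of hydrogen on an aromatic carbon.

The expectation for compound 4 rests on the measured pair: the step of a 1.1-fold lower number from compound 1 to compound 2 (0.05 log units; within the scatter) stayed within the scatter, and the core change a 1.1-fold higher number from compound 1 to compound 3 (0.02 log units; within the scatter) also stayed within it, so the estimated step is a 1.1-fold lower number from compound 3 to compound 4 (0.05 log units; within the scatter). Compound 4 is therefore expected to give about 65000 nM in this assay, with the estimate spanning from 35000 nM to 120000 nM.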

Compound 4, concentration for 50% growth inhibition: 67300 nM
Estimate against measurement, compound 4: 1.0-fold (0.02 log units) below; the measured number falls inside the stated range.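

In this assay, 3-bromophenyl in place of 2-bromophenyl on the carbonyl carbon gives a 1.1-fold lower number from compound 3 to compound 4 (0.03 log units; within the scatter), and this step agrees with the one on the core of compound 1: the same change on two cores in this assay, a 1.1-fold lower number (0.05 log units; within the scatter) from compound 1 to compound 2 and a 1.1-fold lower number (0.03 log units; within the scatter) from compound 3 to compound 4, 1.0-fold (0.02 log units) apart, within the scatter of two such steps

Bromo in place of hydrogen on an aromatic carbon gives a 1.1-fold higher number from compound 2 to compound 4 (0.04 log units; within the scatter), and this step likewise agrees with its earlier counterpart: the same change on two cores in this assay, a 1.1-fold higher number (0.02 log units; within the scatter) from compound 1 to compound 3 and a 1.1-fold higher number (0.04 log units; within the scatter) from compound 2 to compound 4, 1.0-fold (0.02 log units) apart, within the scatter of two such steps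

Both changes therefore carry from one core to the other in the limited sense that each stays within the scatter on both cores, and all four compounds remain in one cluster with no order among them; this does not show that a step large enough to read would transfer between cores, nor does it show that the two changes are independent of each other, since steps this small offer no test of either.

From the compounds shown here alone, it remains open whether anything other than bromine would move the read-out in this assay, for example an amine or a carboxylic acid on the phenyl in place of bromo. Also open, going by these compounds, is whether a longer chain in place of the methyl on the shared core would separate any compounds from this cluster.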